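The source may hold more compounds than are shown below. What is called first, only, known or untested is meant among the compounds shown, and "the series" means these compounds.

Measured so far in a functional assay on SK-OV-3 cells (Homo sapiens) for antiproliferative activity, read by MTT assay, with a stated time of 24 h; on this read-out lower numbers stand for stronger inhibition and higher numbers for weaker inhibition:
- compound 1 `COc1ccc(C(=O)/C=C/c2ccc(-c3ccccc3)cc2)c2c1C=CC(C)(C)O2`: > 10000 nM, which is a limit of the assay and not a number
- compound 2 `COc1ccc(C(=O)/C=C/c2ccc(-n3ccnc3)cc2)c2c1C=CC(C)(C)O2`: 7200 nM
- compound 3 `COc1ccc(C(=O)/C=C/c2ccc([N+](=O)[O-])cc2)c2c1C=CC(C)(C)O2`: 3420 nM

Compound 3 holds the lowest of the two numbers; the nearest is compound 2, and the step of a 2.1-fold lower number from compound 2 to compound 3 (0.32 log units; beyond the scatter) lies beyond the scatter. Compound 1 sits at the limit (the limit of > 10000 nM in this assay, at which 1 of the 3 values shown sits), so its steps are floors only: an at least 1.3-fold lower number from compound 1 to compound 2 (0.14 log units; that floor lies within the scatter), and an at least 2.9-fold lower number from compound 1 to compound 3 (0.46 log units; beyond the scatter).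

Compound 4 `COc1ccc(C(=O)/C=C/c2cccs2)c2c1C=CC(C)(C)O2` is the next case. Relative to compound 3 the change is thiophen-2-yl in place of 4-nitrophenyl on a double-bonded chain carbon bound to a double-bonded chain carbon. For the measured compounds named here, none of the measured steps bears on it directly: each of them exchanges a group on the six-membered aromatic ring of carbon only, and the nitro compound gives the lowest number among them. The step to compound 4 removes the nitro along with that ring and puts in thiophen-2-yl. Going by the values given here, the only guide is that the compounds without nitro, compound 1 and compound 2, sit higher, so the step is expected to run upward, likely at least modest, with a real chance that the assay returns only a limit. Compound 4 is therefore expected to land near 8000 nM, between 3000 nM and 20000 nM. That corresponds to an expected step of a 2.3-fold higher number from compound 3 to compound 4 (0.37 log units; beyond the scatter).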

Compound 4, half-maximal inhibitory concentration: > 10000 nM
Compound 4: only a limit was reported; the forecaster's own chance of this, stated with the estimate: 40%; middle value at least 1.2-fold (0.09 log units) away from the limit.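

In this assay, this change at the position on a double-bonded chain carbon bound to a double-bonded chain carbon replaces the whole 4-nitrophenyl with thiophen-2-yl, and the step is an at least 2.9-fold higher number from compound 3 to compound 4 (0.46 log units; beyond the scatter), the first step shown here that exchanges the aromatic ring on the chain and not only a group on that ring. On these data alone, compound 4 gives > 10000 nM, which is a limit of the assay and not a number, so the step is a floor and its true size stays unknown. Any steps from compound 1 or compound 2 to compound 4 cannot be read, and the upper end of the series is now crowded: the limit of > 10000 nM in this assay, at which 2 of the 4 values shown sit.

As far as these compounds go, it remains open whether the lower number of compound 3 depends on the nitro, on the six-membered aromatic ring of carbon only, or on the two together; a nitro carried on the thiophen-2-yl, or an unsubstituted phenyl, would separate these readings. From the compounds shown here alone, also open in this assay is how an amine or a carboxylic acid in place of the nitro would read, and whether either would come clear of the limit.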